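The compounds below may be only part of what the source reports. "The series", "measured", "known", "first", "only" and "open" are said of these compounds alone.

In a functional assay on SGC-7901 cells (Homo sapiens) for cytotoxicity, read by MTT assay, with a stated time of 72 h (on this read-out lower numbers stand for stronger inhibition and higher numbers for weaker inhibition), compound 1 `Oc1ccc(C2C/C(=N\NC(=S)N3CCOCC3)c3ccc(O)cc3O2)cc1` gives 52200 nM and compound 2 `CCCN(CCC)C(=S)N/N=C1\CC(c2ccc(O)cc2)Oc2cc(O)ccc21` gives 32200 nM. Going by the values given here, compound 2 therefore stands within the scatter of compound 1, its only measured neighbour.

Compound 3 `CCCNC(=S)N/N=C1\CC(c2ccc(O)cc2)Oc2cc(O)ccc21` is the next case, and it differs from compound 2 by hydrogen in place of propyl on an amide-type nitrogen, so that dipropylamino becomes propylamino.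

Among the compounds with values here, one measured step bears on this change: a 1.6-fold lower number from compound 1 to compound 2 (0.21 log units; within the scatter), with dipropylamino in place of morpholin-4-yl on a thiocarbonyl carbon. That step stays within the scatter. Within the data shown here, no measured compound yet carries hydrogen at this nitrogen, so the evidence is thin. No step beyond the scatter is expected in this assay, and neither direction is favoured.

The estimate amounts to an expected 1.1-fold higher number from compound 2 to compound 3 (0.05 log units; within the scatter). For compound 3 the estimated value is 36000 nM, with an expected range of 15000 nM to 85000 nM.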

Compound 3, half-maximal inhibitory concentration: 31200 nM
Compound 3: middle estimate off by 1.2-fold (0.06 log units), on the high side, and the stated range covers the measured number.
By their numbers in this assay, from the lowest: compounds 3, 2 and 1 (each within the scatter of the next).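

Compound 3 is the first shown with hydrogen on the amide-type nitrogen, and in this assay hydrogen in place of propyl gives a 1.0-fold lower number from compound 2 to compound 3 (0.01 log units; within the scatter) as the printed step, so this change does not separate the two compounds. Propylamino in place of morpholin-4-yl on the thiocarbonyl carbon gives a 1.7-fold lower number from compound 1 to compound 3 (0.22 log units; within the scatter) as its step, so morpholin-4-yl, dipropylamino and propylamino all stand within the scatter of each other on this read-out, and the series shows no order among these three groups. No measurement is available that would explain this flat result.

Going by these compounds, whether a longer chain such as octyl, a benzyl group or a plain unsubstituted amino group at this nitrogen would give a step beyond the scatter remains open. Also open, on these data alone, is whether methoxy in place of the hydroxyl groups on the shared core would move the number in this cell assay.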